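A few compounds are considered here, and "the series" means these few. Any claim that something is new, unique, unknown or untested is made for them only; others in the source may bear on it.

Measured compounds in this series:

compound 1 `[N-]=[N+]=N[C@H]1C[C@H](n2cnc3c(NCCCCCO)nc(N)nc32)O[C@@H]1CO` — > 100000 nM
compound 2 `[N-]=[N+]=N[C@H]1C[C@H](n2cnc3c(NCCO)nc(N)nc32)O[C@@H]1CO` — > 100000 nM
compound 3 `C#CCNc1nc(N)nc2c1ncn2[C@H]1C[C@H](N=[N+]=[N-])[C@@H](CO)O1` — > 100000 nM

In an ADME assay on PBMC cells (Homo sapiens) for cytotoxicity, with a stated time of 5 days (a lower number here means a stronger inhibitor, a higher number a weaker inhibitor), compound 1 gives > 100000 nM, which is a limit of the assay and not a number. Compound 2 gives > 100000 nM, also a limit. Compound 3 gives > 100000 nM, again a limit. Compound 3 therefore stands exactly where compound 1 and compound 2 stand: all three values sit at the same limit (the limit of > 100000 nM in this assay, at which 3 of the 3 values shown sit), and none of them is a measured number. Going by the values given here, the steps a step that the two limits leave unreadable from compound 1 to compound 2, a step that the two limits leave unreadable from compound 1 to compound 3 and a step that the two limits leave unreadable from compound 2 to compound 3 are consequently unreadable in size and direction; they show only that neither change in the chain on the ring nitrogen brought a compound off the limit.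

The next compound is compound 4 `CC(C)(CO)Nc1nc(N)nc2c1ncn2[C@H]1C[C@H](N=[N+]=[N-])[C@@H](CO)O1`. It differs from compound 3 by 1-(hydroxymethyl)-1-methylethyl in place of propargyl on a nitrogen on an aromatic ring.

Among the compounds with values here, no measured step bears readably on this change: every step so far is hidden by the limit. With three compounds of this series at the limit and no numbered value anywhere, compound 4 is expected to behave the same way. The step from compound 3 to compound 4 is expected to be a step that the limit leaves unreadable from compound 3 to compound 4, that is, nothing beyond the scatter and most likely again only a limit. For compound 4 the expected value is 150000 nM, with a range from 100000 nM to 300000 nM.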

Compound 4, half-maximal inhibitory concentration: > 100000 nM
Compound 4: no number, only a limit (the forecaster's own chance of this, stated with the estimate: 85%); the middle value does not contradict the limit.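

In this assay compound 4 gives > 100000 nM as a limit and not a number. Its steps from compound 1, compound 2 and compound 3 therefore cannot be read in size or direction, and all four compounds stand at the same limit: the limit of > 100000 nM in this assay, at which 4 of the 4 values shown sit.

Which group on the nitrogen on the aromatic ring, if any, would bring a compound off this limit in this assay remains open.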